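Trimethoxybenzoyl pyrroles: aminophenyl to methoxyphenyl on the carbon

The source may report more compounds than this note shows. Statements on the series, on what has been measured and on what is new or still open speak of the compounds shown alone.

Measured so far, in a functional assay on MCF7 cells (Homo sapiens) for cytotoxicity, read by MTT assay, with a stated time of 96 h; a higher number here means a weaker inhibitor, a lower number a stronger inhibitor:
- compound 1 `COc1cc(C(=O)c2cn(-c3ccccc3)cc2-c2ccc(N)cc2)cc(OC)c1OC` gives 9 nM
- compound 2 `COc1cc(C(=O)c2cn(-c3ccccc3C)cc2-c2ccccc2)cc(OC)c1OC` gives 2200 nM
- compound 3 `COc1cc(C(=O)c2cn(-c3ccc(N)cc3)cc2-c2ccccc2)cc(OC)c1OC` gives 35 nM

Compound 1 has the lowest number of the three in this assay. Its nearest neighbour is compound 3, whose number is higher by a step beyond the scatter; compound 2 sits much further up.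

Among the measured compounds shown here, the one step between compounds that differ in a single place is a 63-fold lower number from compound 2 to compound 3 (1.80 log units; beyond the scatter); it concerns the group on the aromatic nitrogen, where a 4-aminophenyl in place of 2-methylphenyl brought the number sharply down.

Compound 4 `COc1ccccc1-c1cn(-c2ccccc2)cc1C(=O)c1cc(OC)c(OC)c(OC)c1` is yet to be measured in this assay. Relative to compound 1 the change is 2-methoxyphenyl in place of 4-aminophenyl on an aromatic carbon. For the measured compounds named here, no measured step touches the group on the aromatic carbon, so the step from compound 2 to compound 3 bears on this only by analogy: there the 4-aminophenyl went with the lower number, and a phenyl carrying a small group in the same position as the methoxy here went with the much higher one. On that analogy the number for compound 4 is expected to rise, though less than the step from compound 2 to compound 3, since the site differs. The expected step is a 22-fold higher number from compound 1 to compound 4 (1.35 log units; beyond the scatter), and compound 4 is estimated at 200 nM, within 40 nM to 1500 nM.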

Compound 4, half-maximal inhibitory concentration: 190 nM
Beside the measured number, compound 4's estimate is 1.1-fold (0.02 log units) above it; measured number inside the range.
By their numbers in this assay, from the lowest: compound 1; then compound 3; then compound 4; then compound 2.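

In this assay, the group on the aromatic carbon now has a measured step of its own: 2-methoxyphenyl in place of 4-aminophenyl gives a 21-fold higher number from compound 1 to compound 4 (1.32 log units; beyond the scatter). The position is therefore sensitive to which substituted phenyl it carries, with the phenyl on the ring nitrogen held constant, and the earlier step at that nitrogen could show this only by analogy. No measurement shown explains this step.

Among the compounds shown here, the single step swaps two things at once, the amino group leaving and the methoxy group entering, each at its own place on the phenyl, so their separate contributions remain unresolved. An unsubstituted phenyl, 4-methoxyphenyl or 2-aminophenyl on this carbon would each separate the identity of the substituent from its place on the ring.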